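Fluoro for Chloro on the Benzyl Thioether Arm

The source may report more compounds than this note shows. Statements on the series, on what has been measured and on what is new or still open speak of the compounds shown alone.

Three compounds share one core and were tested in a functional assay on the whole organism (artery, strain albino) with Rattus norvegicus as the target, with a stated time of 15 min, at a dose of 10 mg/kg by the oral route; a higher number here means more inhibition at the dose given (going by the name of the read-out), a lower number less inhibition. Compound 1 `CC1=C(C(=O)Nc2ccc(Br)cc2)C(c2ccc(Cl)cc2Cl)N=C(SCc2ccc(F)cc2)N1` gives 3.6%, compound 2 `COc1ccc(C2N=C(SCc3cccc(Cl)c3)NC(C)=C2C(=O)Nc2ccc(Br)cc2)cc1` gives 3.1%, and compound 3 `COc1ccc(C2N=C(SCc3ccc(Cl)cc3)NC(C)=C2C(=O)Nc2ccc(Br)cc2)cc1` gives 3.1%. Compound 3 thus sits level with compound 2, and its gap to compound 1 lies within the scatter. Compound 4 `COc1ccc(C2N=C(SCc3ccc(F)cc3)NC(C)=C2C(=O)Nc2ccc(Br)cc2)cc1` differs from compound 3 by fluoro in place of chloro on an aromatic carbon. The only single step shown, no change at the digits printed from compound 2 to compound 3 (within the scatter), moved the chloro within the same ring and shifted nothing beyond the scatter; compound 1, which also carries a 4-fluorobenzyl, sits in the same low band. No change beyond the scatter is therefore expected in this assay. Compound 4 is expected to give 3.3%, likely between 0% and 12%. That expectation amounts to a step of a number 0.2 percentage points higher from compound 3 to compound 4 (within the scatter).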

Compound 4, a percentage reported as inhibition, in the whole organism at one dose (the size of the read-out at that dose, not a potency): 3.6%
The estimate for compound 4 lay 0.3 percentage points below the measured number; the range from low to high includes it.
By their numbers in this assay, from the lowest: compounds 2, 3, 1 and 4 (each within the scatter of the next).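

In this assay, the change of halogen on this ring gives a number 0.5 percentage points higher from compound 3 to compound 4 (within the scatter), so chloro and fluoro at this place read alike, whereas the earlier step only moved the chloro. The step of a number 0.5 percentage points higher from compound 2 to compound 4 (within the scatter) agrees, and the step of no change at the digits printed from compound 1 to compound 4 (within the scatter) shows that the swap on the saturated ring carbon also leaves the number within the scatter when the 4-fluorobenzyl is kept. Nothing available explains why these numbers stay together. Whether an amine or a carboxylic acid at this place would give a different number remains open, since only halogens are shown there.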